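Positional shift of fluorine on a phenylalkyne series

A few compounds are considered here, and "the series" means these few. Any claim that something is new, unique, unknown or untested is made for them only; others in the source may bear on it.

Measured compounds:
compound 1, `COC(=O)c1sc2ccccc2c1C#Cc1ccc(OC)cc1`, 90600 nM
compound 2, `COC(=O)c1sc2ccccc2c1C#Cc1ccccc1F`, 40900 nM

Of the compounds shown here, two built on the shared core have been tested in a functional assay on MCF7 cells (Homo sapiens) for cytotoxicity, read by sulforhodamine B assay, with a stated time of 48 h; on this read-out lower numbers stand for stronger inhibition of growth and higher numbers for weaker inhibition of growth. Compound 1 gives 90600 nM in this assay, and compound 2 gives 40900 nM. Compound 2 therefore stands at the lowest of the two numbers; its nearest neighbour, compound 1, sits beyond the scatter with a higher number. Within the data shown here, the two measured compounds differ in more than one place, so no single step between them has been worked out, and only their two values are available for comparison.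

The next compound, compound 3, `COC(=O)c1sc2ccccc2c1C#Cc1ccc(F)cc1`, has not yet been measured. It differs from compound 2 by 4-fluorophenyl in place of 2-fluorophenyl on a triple-bonded carbon. Among the measured compounds shown here, with no measured pair of this kind on record, the size of the step in this assay cannot be derived from the data; a modest step toward a higher number, close to the scatter, is expected, since the other measured compound, compound 1, gave 90600 nM. Compound 3 is thus estimated at 60000 nM, within 20000 nM to 180000 nM, which means an expected step of a 1.5-fold higher number from compound 2 to compound 3 (0.17 log units; within the scatter).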

Compound 3, concentration for 50% growth inhibition: 60600 nM
The estimate for compound 3 lay 1.0-fold (0.00 log units) below the measured number; measured number inside the range.
By their numbers in this assay, from the lowest: compounds 2, 3 and 1 (each within the scatter of the next, the first and the last beyond it).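

In this assay, replacing 2-fluorophenyl with 4-fluorophenyl on the triple-bonded carbon gives a 1.5-fold higher number from compound 2 to compound 3 (0.17 log units; within the scatter), so this change in where the same atoms are joined is not resolved from the scatter. Among these compounds, compound 3 also provides the first comparison in which only one place differs from compound 1: fluoro in place of methoxy on an aromatic carbon gives a 1.5-fold lower number from compound 1 to compound 3 (0.17 log units; within the scatter), and this exchange is likewise not resolved in this read-out. No supporting measurement bears on the size of either step.

The compounds shown leave open whether an amine, a carboxylic acid or a longer chain on the phenyl ring would produce a step beyond the scatter. They also leave open whether replacing the methyl ester of the shared core with a carboxylic acid or an amide would change the number by more than the two small steps seen with these phenyl groups.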